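A few compounds are considered here, and "the series" means these few. Any claim that something is new, unique, unknown or untested is made for them only; others in the source may bear on it.

In a functional assay on HL-60 cells (Homo sapiens) for cytotoxicity, read by luminescence and CellTiter-Glo, with a stated time of 3 days (on this read-out higher numbers stand for weaker inhibition and lower numbers for stronger inhibition), compound 1 (`O=C(Nc1cc(C(F)(F)F)cc(C(F)(F)F)c1)c1cc(Cl)c(F)cc1O`) gives 430 nM and compound 2 (`N#Cc1ccc(NC(=O)c2cc(Cl)ccc2O)c(Cl)c1`) gives 500 nM as its number, so the two values lie within the scatter of each other. Compound 3 (`O=C(Nc1cc(C(F)(F)F)cc(C(F)(F)F)c1)c1cc(Br)c(F)cc1O`) differs from compound 1 by a single swap (bromo in place of chloro on an aromatic carbon): bromo in place of chloro on an aromatic carbon, para to a hydroxy group and ortho to a fluoro group. Going by the values given here, no measured pair shows this swap, so in this assay no step beyond the scatter is expected, in either direction. The estimated change is small (a 1.1-fold lower number from compound 1 to compound 3 (0.03 log units; within the scatter)). Compound 3 is expected at 400 nM with a range of 180 nM to 900 nM around that estimate.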

Compound 3, half-maximal inhibitory concentration: 250 nM
The estimate for compound 3 lay 1.6-fold (0.20 log units) above the measured number; the measured number falls inside the stated range.
By their numbers in this assay, from the lowest: compounds 3, 1 and 2 (each within the scatter of the next).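

In this assay, bromo in place of chloro, para to a hydroxy group and ortho to a fluoro group, gives a 1.7-fold lower number from compound 1 to compound 3 (0.24 log units; within the scatter), the first direct test of this position. Such a step cannot be told apart from repeat measurements, so chloro and bromo cannot be ranked here. No measured evidence accounts for the numbers of compound 1 and compound 3.

Only these two groups are shown at this position. On these data alone, whether an amine, a methoxy group or a carboxylic acid there would give a step beyond the scatter remains open.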